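This account rests on a few compounds, and the source may have more. Where it says the series, first, only, none or still open, it means among the compounds named here.

Measured compounds:
- compound 1 `CCS(=O)(=O)c1ccc(CN(CC(C)C)S(=O)(=O)c2ccc3c(c2)C(O)CC(C2CCOCC2)O3)nc1` gives 1.42 in a physicochemical assay for lipophilicity, at pH 7.4; a higher number here means a more lipophilic compound, a lower number a more polar compound
- compound 2 `CCc1ccc(N(CC(C)C)S(=O)(=O)c2ccc3c(c2)C(O)CC(C2CCN(C(=O)C4CCCC4)CC2)O3)cc1` gives 5.04 in this assay

Compound 1 is the lower of the two numbers; compound 2 lies well beyond the scatter above it. Within the data shown here, no pair of measured compounds differs in a single place, so no measured step is available.

Compound 3 `Cc1ccc(N(CC(C)C)S(=O)(=O)c2ccc3c(c2)C(O)CC(C2CCOCC2)O3)c(C)c1` is not yet measured. It differs from compound 1 as follows: 2,4-dimethylphenyl in place of (5-(ethylsulfonyl)pyridin-2-yl)methyl on a sulfonamide nitrogen. The group that leaves carries the only hydrogen-bond acceptors of the exchanged part; the group that enters carries none and is carbon only. A substantial step upward in this assay is therefore expected, clearly beyond the scatter, though compound 3 is not expected to reach the number of compound 2, which carries a different group on the shared core.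

For compound 3 the estimate is 3.8, with a range of 3.2 to 4.5, corresponding to an expected step of a number 2.38 log units higher from compound 1 to compound 3 (beyond the scatter).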

Compound 3, distribution coefficient: 4.19
For compound 3 the middle estimate is 0.39 log units below the measured one; low and high end bracket the measured number.
By their numbers in this assay, from the lowest: compound 1; then compound 3; then compound 2.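

In this assay, among these compounds, the exchange to 2,4-dimethylphenyl from (5-(ethylsulfonyl)pyridin-2-yl)methyl on a sulfonamide nitrogen gives a number 2.77 log units higher from compound 1 to compound 3 (beyond the scatter) with the rest of the structure unchanged, the first step that can be tied to one place. The exchange replaces the ethylsulfonyl group, the ring nitrogen and the methyl link together, so the step belongs to the whole exchange and not to any one of these parts. No measurement available here bears on the origin of the step.

On these data alone, how the step divides among those parts remains open, and a benzyl group or an unsubstituted phenyl on this nitrogen would speak to that. Also open, as far as these compounds go, is how an amine or a carboxylic acid on the ring at this position would read.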